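The compounds below may be only part of what the source reports. "The series", "measured", "known", "first", "only" and "open" are said of these compounds alone.

In a functional assay on MDA-MB-231 cells (Homo sapiens) for antiproliferative activity, read by MTT assay, with a stated time of 48 h (on this read-out higher numbers stand for weaker inhibition and lower numbers for stronger inhibition), compound 1 (`CN1CCN(c2ccc(-c3cc4c(N5CCN(C(=O)Nc6ccc(OC(F)(F)F)cc6)CC5)ncnc4s3)cc2)CC1`) gives 4600 nM, compound 2 (`CN1CCN(c2ccc(-c3cc4c(N5CCN(C(=O)Nc6cccc(F)c6)CC5)ncnc4s3)cc2)CC1`) gives 13200 nM and compound 3 (`CC(C)c1cccc(C(C)C)c1NC(=O)N1CCN(c2ncnc3sc(-c4ccc(N5CCN(C)CC5)cc4)cc23)CC1`) gives 8430 nM. Compound 3 therefore stands within the scatter of both other compounds: the measured steps are a 1.8-fold higher number from compound 1 to compound 3 (0.26 log units; within the scatter) and a 1.6-fold lower number from compound 2 to compound 3 (0.19 log units; within the scatter). Compound 4 (`CN1CCN(c2ccc(-c3cc4c(N5CCN(C(=O)Nc6cc(C(F)(F)F)ccc6F)CC5)ncnc4s3)cc2)CC1`) differs from compound 3 at the same place, with 2-fluoro-5-(trifluoromethyl)phenyl in place of 2,6-diisopropylphenyl on an amide-type nitrogen. All three measured steps are exchanges at this nitrogen, so all three bear on the change. The widest of them, a 2.9-fold higher number from compound 1 to compound 2 (0.46 log units; beyond the scatter), is only modest, so no step beyond the scatter is expected in this assay. The estimated step is a 1.2-fold lower number from compound 3 to compound 4 (0.08 log units; within the scatter). For compound 4 the estimated value is 7000 nM, with an expected range of 3000 nM to 16000 nM.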

Compound 4, half-maximal inhibitory concentration: 9090 nM
The estimate for compound 4 lay 1.3-fold (0.11 log units) below the measured number, within the range that was stated.
By their numbers in this assay, from the lowest: compounds 1, 3, 4 and 2 (each within the scatter of the next, the first and the last beyond it).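

In this assay, replacing 2,6-diisopropylphenyl with 2-fluoro-5-(trifluoromethyl)phenyl on the amide-type nitrogen leaves the read-out within the scatter (a 1.1-fold higher number from compound 3 to compound 4 (0.03 log units; within the scatter)), so this change of ring substituents does not register in this assay. Compound 4 also lies within the scatter of the other two compounds (a 1.5-fold lower number from compound 2 to compound 4 (0.16 log units; within the scatter); a 2.0-fold higher number from compound 1 to compound 4 (0.30 log units; within the scatter)), which places this fourth substituted phenyl group among the earlier three without separating it from any of them. The step between the 4-(trifluoromethoxy)phenyl and 3-fluorophenyl compounds therefore remains the only one beyond the scatter (a 2.9-fold higher number from compound 1 to compound 2 (0.46 log units; beyond the scatter)), and no measurement at hand accounts for the closeness of these numbers.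

All four compounds carry a substituted phenyl group at this nitrogen. As far as these compounds go, whether an amine or a carboxylic acid on that ring, or a plain alkyl chain in its place, would shift the read-out beyond the scatter remains open.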